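A few compounds are considered here, and "the series" means these few. Any claim that something is new, unique, unknown or untested is made for them only; others in the source may bear on it.

Working notes on the series in an assay for inhibition of alpha-N-acetylgalactosaminidase (Gallus gallus), tested at 1000 uM; a higher number here means more inhibition at the concentration tested (going by the name of the read-out), a lower number less inhibition. Compound 1 `O=C(O)[C@H]1NCC=C[C@@H]1O` gives 25% in this assay. Among the compounds with values here, compound 2 `O=C(O)[C@@H]1NC[C@@H](O)[C@H](O)[C@@H]1O` gives 10% in this assay, the lowest of the two numbers so far; its nearest neighbour is compound 1, whose number is higher by a margin beyond the usual scatter. Within the data shown here, no pair of measured compounds differing in one place is available, so nothing is known about how single changes move the read-out.

Compound 3 `O=C(O)[C@H]1NC[C@@H](O)[C@H](O)[C@H]1O` is not yet measured. Its relation to compound 2 is the two compounds have the same atoms and bonds and differ only in configuration as drawn: 2 of 4 stereo elements differ; a stereocentre at a saturated ring carbon is drawn R in compound 2 and S in compound 3; a stereocentre at a saturated ring carbon is drawn R in compound 2 and S in compound 3. Among the measured compounds shown here, with no measured step of this kind, the direction is open; a change that is unseen is expected to move this assay only modestly, in either direction. For compound 3 the expected step of a number 10 percentage points higher from compound 2 to compound 3 (within the scatter) is small and upward. Compound 3 is estimated at 20% in this assay, within a range from 5% to 45%.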

Compound 3, a percentage reported as inhibition, at one concentration (the size of the read-out at that concentration, not a potency): 4.2%
Compound 3: the middle estimate sits 15.8 percentage points above what was measured; the measured number lies below the stated range.
By their numbers in this assay, from the lowest: compounds 3 and 2 (each within the scatter of the next); then compound 1.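

In this assay the series now has its first readable step, a number 5.8 percentage points lower from compound 2 to compound 3 (within the scatter). Two of the four stereo elements, both stereocentres at saturated ring carbons, are drawn differently in this pair, yet the read-out does not separate the two compounds, so for this pair the combined change in configuration has no effect that can be told from the scatter. This is the first comparison in which nothing but stereochemistry varies: the fact that compounds 2 and 3 differ only in the configuration as drawn

As far as these compounds go, whether either stereocentre taken alone would move the read-out stays open, as the two change together here and a change at one could be masked by the other. Also open, from the compounds shown here alone, is how this assay would respond to a methyl ester or a primary amide in place of the carboxylic acid, or to an amine in place of a ring hydroxyl.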